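Enantiomer swap on a pyrrolidinyl ether in receptor binding

The source may report more compounds than this note shows. Statements on the series, on what has been measured and on what is new or still open speak of the compounds shown alone.

Measured so far:
compound 1 `Nc1ccc2cccc(OCCCNCc3ccc(Cl)c(C(F)(F)F)c3)c2n1` — 5 nM
compound 2 `Nc1ccc2cccc(O[C@H]3CCN(Cc4ccccc4)C3)c2n1` — 120 nM

Two compounds share the amino-quinoline core and differ in the ether-linked amine arm. In an assay on cells with melanin-concentrating hormone receptor 1 (Homo sapiens) as the target, read by radioligand binding (a higher number here means a weaker inhibitor, a lower number a stronger inhibitor), compound 1 gives 5 nM, a value that marks it as the stronger binder of the pair. Compound 2 carries a benzyl-substituted pyrrolidinyl ether in place of the open chain of compound 1. In this assay compound 2 gives 120 nM and thus holds the highest number of the two measured; the gap to compound 1 lies well beyond the usual scatter.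

Compound 3 `Nc1ccc2cccc(O[C@@H]3CCN(Cc4ccccc4)C3)c2n1` is the unmeasured partner of compound 2. The change is this: the two compounds have the same atoms and bonds and differ only in configuration as drawn: 1 of 1 stereo elements differ; a stereocentre at a saturated ring carbon is drawn S in compound 2 and R in compound 3. Nothing is added or removed; only the drawn configuration at that ring carbon is inverted. Among the measured compounds shown here, no measured pair in this set shows what such an inversion does, so neither the direction nor the size of the step in this assay can be read from the numbers at hand. The two enantiomers could sit within the scatter of each other or apart by a wide margin in either direction. On that basis the value of compound 3 is estimated near the level of compound 2, with a broad range, as a step of a 1.3-fold higher number from compound 2 to compound 3 (0.10 log units; within the scatter), giving an expected 150 nM with a range from 20 nM to 1200 nM.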

Compound 3, half-maximal inhibitory concentration: 580 nM
Compound 3: middle estimate off by 3.9-fold (0.59 log units), on the low side; measured number inside the range.
By their numbers in this assay, from the lowest: compound 1; then compound 2; then compound 3.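

In this assay, among the compounds shown here, inverting the configuration at the saturated ring carbon from S to R gives a 4.8-fold higher number from compound 2 to compound 3 (0.68 log units; beyond the scatter), so this stereocentre has a measurable effect on the read-out, which no earlier pair could show. Of the two enantiomers, the S form drawn in compound 2 has the lower number, which places the preference in this pair on that side, with a step that is modest in size but clear of the usual scatter. Since no atom or bond changes, the step can be traced to the configuration alone because of one structural fact: the fact that compounds 2 and 3 differ only in the configuration as drawn.

Compound 1 differs from both enantiomers in more than one place, so it cannot show whether this preference holds with its open chain and substituted benzyl group, and the pair speaks only for the unsubstituted benzyl pyrrolidinyl ether. Whether the S form would keep its lower number with a phenethyl group on the ring nitrogen, or with a piperidine ring in place of the pyrrolidine, remains open in the compounds shown here.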